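Swapping Fluoro for Chloro on a Shared Core

A few compounds are considered here, and "the series" means these few. Any claim that something is new, unique, unknown or untested is made for them only; others in the source may bear on it.

Measured compounds in a functional assay on PC-3 cells (Homo sapiens) for cytotoxicity, read by MTT assay, with a stated time of 72 h; on this read-out lower numbers stand for stronger inhibition and higher numbers for weaker inhibition:
compound 1, `O=S(=O)(c1ccccc1)c1nc2ccccc2nc1Nc1ccc(F)cc1`: 14200 nM
compound 2, `O=S(=O)(c1ccccc1)c1nc2ccccc2nc1Nc1ccc(Cl)cc1`: 15300 nM
compound 3, `COc1ccc(S(=O)(=O)c2nc3ccccc3nc2Nc2ccc(F)cc2)cc1`: 2200 nM

Compound 4, `COc1ccc(S(=O)(=O)c2nc3ccccc3nc2Nc2ccc(Cl)cc2)cc1`, has not been measured. It differs from compound 3 by chloro in place of fluoro on an aromatic carbon. The same change appears once already: compound 2 differs from compound 1 by chloro in place of fluoro on an aromatic carbon, and in this assay that gave a 1.1-fold higher number from compound 1 to compound 2 (0.03 log units; within the scatter). The cores of compound 3 and compound 1 differ by methoxy in place of hydrogen on an aromatic carbon, which gave a 6.5-fold lower number from compound 1 to compound 3 (0.81 log units; beyond the scatter). Since the place of the fluoro-to-chloro change is described in identical terms for both pairs, it is the same change on a different core. The step from compound 3 to compound 4 is therefore expected to be small, about a 1.1-fold higher number from compound 3 to compound 4 (0.04 log units; within the scatter), because the earlier one was a 1.1-fold higher number from compound 1 to compound 2 (0.03 log units; within the scatter). Compound 4 is expected to give about 2400 nM, likely between 1200 nM and 4800 nM.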

Compound 4, half-maximal inhibitory concentration: 31800 nM
The estimate for compound 4 lay 13-fold (1.12 log units) below the measured number, and the stated range ends below it.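

In this assay, chloro in place of fluoro did not carry over from one core to the other, giving a 14-fold higher number from compound 3 to compound 4 (1.16 log units; beyond the scatter), and this step differs clearly from the earlier one: the same change on two cores in this assay, a 1.1-fold higher number (0.03 log units; within the scatter) from compound 1 to compound 2 and a 14-fold higher number (1.16 log units; beyond the scatter) from compound 3 to compound 4, 13-fold (1.13 log units) apart, beyond the scatter of two such steps

Methoxy in place of hydrogen also changed direction, giving a 2.1-fold higher number from compound 2 to compound 4 (0.32 log units; beyond the scatter) with chloro present, where it had lowered the number with fluoro present: the same change on two cores in this assay, a 6.5-fold lower number (0.81 log units; beyond the scatter) from compound 1 to compound 3 and a 2.1-fold higher number (0.32 log units; beyond the scatter) from compound 2 to compound 4, 13-fold (1.13 log units) apart, beyond the scatter of two such steps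

These four compounds show that the two changes do not add up independently, so a step seen on one core is a poor guide to the other, but they do not show why.

On these data alone, whether bromo or methyl in place of chloro would behave like fluoro on the methoxy core remains open. So does whether an amine in place of methoxy would show the same dependence.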